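A few compounds are considered here, and "the series" means these few. Any claim that something is new, unique, unknown or untested is made for them only; others in the source may bear on it.

Of the compounds shown here, three of a shared core have been measured in a functional assay on HCT-116 cells (Homo sapiens) for inhibition, read by MTT assay, with a stated time of 48 h; a lower number here means a stronger inhibitor, a higher number a weaker inhibitor. Compound 1 `COc1cc2ccc(=O)oc2cc1OC(=O)c1c(C)noc1-c1ccccc1` gives 22700 nM in this assay. Compound 2 `COc1cc2ccc(=O)oc2cc1OC(=O)c1c(C)noc1-c1ccc([N+](=O)[O-])cc1` gives 9210 nM in this assay. Compound 3 `COc1cc2ccc(=O)oc2cc1OC(=O)c1c(-c2ccc(Cl)cc2)n[nH]c1C` gives 13800 nM in this assay. Compound 3 therefore stands between the other two on the numbers seen so far, with compound 2 as its nearest neighbour, and both of its gaps, to compound 2 and to compound 1, lie within the usual scatter of repeated measurements, so no order among the three can be claimed.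

Compound 4 `COc1cc2ccc(=O)oc2cc1OC(=O)c1c(-c2ccc([N+](=O)[O-])cc2)n[nH]c1C` differs from compound 3 in one place: nitro in place of chloro on an aromatic carbon. Within the data shown here, the only measured step that bears on this change is a 2.5-fold lower number from compound 1 to compound 2 (0.39 log units; beyond the scatter), in which the aromatic ring gained a nitro group where it had carried none. Here the nitro replaces a chloro instead, so that step is only a partial guide, and a somewhat smaller move toward a lower number seems reasonable for compound 4.

Compound 4 is therefore expected to show a 1.7-fold lower number from compound 3 to compound 4 (0.24 log units; within the scatter) in this assay. The estimate for compound 4 is 8000 nM, with a range from 3500 nM to 20000 nM.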

Compound 4, half-maximal inhibitory concentration: > 25000 nM
Compound 4 gave a limit, no number; the forecaster's own chance of this, stated with the estimate: 5%; middle value at least 3.1-fold (0.49 log units) away from the limit.
By their numbers in this assay, from the lowest: compounds 2, 3 and 1 (each within the scatter of the next, the first and the last beyond it). At a limit, above all of these: compound 4.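

In this assay, compound 4 gives only a limit of the assay, not a number: the limit of > 25000 nM in this assay, at which 1 of the 4 values shown sits. At this position, on an aromatic carbon para to a large group, the change from 4-chlorophenyl to 4-nitrophenyl gives an at least 1.8-fold higher number from compound 3 to compound 4 (0.25 log units; that floor lies within the scatter). The earlier nitro step, a 2.5-fold lower number from compound 1 to compound 2 (0.39 log units; beyond the scatter), had nitro in place of hydrogen and went toward a lower number, so the two nitro steps do not point the same way, and the earlier step proved a poor guide to a swap of chloro for nitro on this other series, even though the floor of the new step alone does not clear the usual scatter.

Going by these compounds, how far past the limit compound 4 truly lies stays open, and with it the real size of this step, which could be barely beyond the scatter or much larger. The compounds shown also leave open how an amine or a carboxylic acid at this same place on the aromatic ring would read in this assay, and whether any group there would give a number clearly lower than chloro does.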